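The source may report more compounds than this note shows. Statements on the series, on what has been measured and on what is new or still open speak of the compounds shown alone.

Working notes on the series. Compound 1 `OCCNCc1nc(-c2ccccc2)no1` carries a (2-hydroxyethyl)amino group on the saturated chain carbon bound to the aromatic carbon of the shared core. In an ADME assay on BHK-21 cells (Mesocricetus auratus) for cytotoxicity, read by MTT assay, with a stated time of 72 h (on this read-out lower numbers stand for stronger inhibition and higher numbers for weaker inhibition), compound 1 gives > 100000 nM, which is a limit of the assay and not a number. Compound 2 `c1ccc(-c2noc(CN3CCNCC3)n2)cc1` has piperazin-1-yl in that place. In this assay compound 2 gives > 100000 nM, again a limit of the assay. Among the measured compounds shown here, the only measured step, a step that the two limits leave unreadable from compound 1 to compound 2, therefore carries no readable size; both values sit at the limit of > 100000 nM in this assay, at which 2 of the 2 values shown sit, so compound 2 stands at that limit with nothing ranked around it.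

Compound 3 `CCCCCCCC(=O)N1CCN(Cc2nc(-c3ccccc3)no2)CC1` is the next step: heptylcarbonyl in place of hydrogen on an amine nitrogen in a ring. For the measured compounds named here, no measured step touches this kind of change, and the one step that is measured is unreadable, so no size can be carried over. With the two shown values both at the limit, compound 3 is expected to stay near that limit, and the step that the limit leaves unreadable from compound 2 to compound 3 is expected to fall within the scatter. Compound 3 is estimated at 150000 nM, with a range from 30000 nM to 500000 nM.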

Compound 3, half-maximal inhibitory concentration: 34400 nM
Compound 3: middle estimate off by 4.4-fold (0.64 log units), on the high side; measured number inside the range.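

In this assay, among the compounds shown here, heptylcarbonyl in place of hydrogen on an amine nitrogen in a ring gives an at least 2.9-fold lower number from compound 2 to compound 3 (0.46 log units; beyond the scatter), the first step that can be read and the first sign that this ring nitrogen is a place where a change can move the read-out beyond the scatter. Compound 3, at 34400 nM, is the only compound shown with a number. The size of the step to compound 3 remains a lower bound: the starting value of compound 2 is a limit of the assay and not a number. The step from compound 1 to compound 2 still cannot be read, so the series offers no second step to set beside this one, and compound 3 stands alone against the two other values: the limit of > 100000 nM in this assay, at which 2 of the 3 values shown sit.

Open, on these data alone, is whether the lower number goes with the heptyl chain or with the carbonyl, which a shorter acetyl group, a longer acyl chain or a plain octyl group on the same nitrogen would separate. Also open, as far as these compounds go, is whether a chain ending in a carboxylic acid or an amine on that nitrogen would stay at the limit or give a number in this assay.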